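This account rests on a few compounds, and the source may have more. Where it says the series, first, only, none or still open, it means among the compounds named here.

Measured compounds:
Compound 1 `O=Cc1ccc(-c2cn3ccnc3c(-c3ccc4ncn(C5CCCCC5)c4c3)n2)cc1` — 20.7%
Compound 2 `Clc1ccc(-c2cn3ccnc3c(-c3ccc4ncn(C5CCCCC5)c4c3)n2)cc1` — 13.5%
Compound 3 `Cc1cccc(-c2cn3ccnc3c(-c3ccc4ncn(Cc5ccccc5)c4c3)n2)c1` — 4.72%

In a functional assay on SN12C cells (Homo sapiens) for inhibition, read by sulforhodamine B assay, with a stated time of 48 h, tested at 10 uM (on this read-out lower numbers stand for less inhibition and higher numbers for more inhibition at the one concentration tested (going by the name of the read-out)), compound 3 gives the lowest of the three numbers, though the value of compound 2 stands within the scatter of it and only the value of compound 1 lies beyond the scatter. For the measured compounds named here, the one step between compounds that differ in a single place is a number 7.2 percentage points lower from compound 1 to compound 2 (within the scatter), and it stays within the scatter.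

Compound 4 `c1ccc(Cn2cnc3ccc(-c4nc(-c5cccc6ccccc56)cn5ccnc45)cc32)cc1` has not yet been measured. It differs from compound 3 by naphthalen-1-yl in place of 3-methylphenyl on an aromatic carbon. Going by the values given here, no measured pair shows this exchange, so the one step that exists bears on it only loosely: a change of the group on the same outer ring of the shared core gave a step within the scatter. A step beyond the scatter is therefore not expected in this assay in either direction, and compound 4 is estimated at 9% with a range from 0% to 25%, meaning an expected step of a number 4.3 percentage points higher from compound 3 to compound 4 (within the scatter).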

Compound 4, a percentage reported as inhibition, at one concentration (the size of the read-out at that concentration, not a potency): 5.62%
Estimate against measurement, compound 4: 3.4 percentage points above; the range from low to high includes it.
By their numbers in this assay, from the lowest: compounds 3, 4, 2 and 1 (each within the scatter of the next, the first and the last beyond it).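

In this assay, replacing 3-methylphenyl with naphthalen-1-yl, which has 2 six-membered aromatic rings of carbon only, gives a number 0.9 percentage points higher from compound 3 to compound 4 (within the scatter). The earlier step, a number 7.2 percentage points lower from compound 1 to compound 2 (within the scatter), came from an exchange at the same aromatic carbon of the shared core, but with cyclohexyl on the core, whereas this one carries benzyl there; at this position, both exchanges shown stay within the scatter, with either substituent on the core. No independent measurement is available to explain this result.

Going by these compounds, it remains open whether an amine or a carboxylic acid on the outer ring at this carbon would give a step beyond the scatter. Whether benzyl and cyclohexyl differ in their effect also remains open, as no pair shown differs only in that place.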